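A few compounds are considered here, and "the series" means these few. Any claim that something is new, unique, unknown or untested is made for them only; others in the source may bear on it.

Compound 2 `N#CCn1c(-c2ccco2)nc2ccccc21`: 88100 nM
Compound 1 `Cc1ccc(-c2nc3ccccc3n2CC(=O)N/N=C/c2ccccc2Cl)o1`: 21300 nM

Of the two compounds measured in a functional assay on MCF7 cells (Homo sapiens) for cytotoxicity, read by sulforhodamine B assay, with a stated time of 48 h (on this read-out lower numbers stand for stronger inhibition and higher numbers for weaker inhibition), compound 2 gives the highest number, 88100 nM, while compound 1 gives 21300 nM, a gap beyond the usual scatter. Compound 3 `N=C(Cn1c(-c2ccco2)nc2ccccc21)NN` differs from compound 2 by a group of 4 heavy atoms (1 carbon, 3 nitrogen; no ring) in place of a group of 2 heavy atoms (1 carbon, 1 nitrogen; no ring), on a saturated chain carbon bound to an aromatic nitrogen. Among the compounds with values here, no measured pair shows this change, so its effect cannot be read from the data; the move from compound 2 to compound 3 is expected to be small, with no clear direction, and may well stay within the scatter. Compound 3 is therefore estimated at 60000 nM, within 15000 nM to 250000 nM, which corresponds to an expected step of a 1.5-fold lower number from compound 2 to compound 3 (0.17 log units; within the scatter).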

Compound 3, half-maximal inhibitory concentration: 53100 nM
The estimate for compound 3 lay 1.1-fold (0.05 log units) above the measured number, and the stated range covers the measured number.
By their numbers in this assay, from the lowest: compound 1; then compounds 3 and 2 (each within the scatter of the next).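

In this assay, putting the group of 4 heavy atoms in place of the cyano on the saturated chain carbon bound to an aromatic nitrogen gives a 1.7-fold lower number from compound 2 to compound 3 (0.22 log units; within the scatter). At this position, then, a group with 3 hydrogen-bond donors can replace one with none while the two numbers stay indistinguishable. Nothing shown here gives a reason for this result. Going by these compounds, whether a carboxylic acid, an amine or a longer chain at this position would also leave the number unmoved remains open. Compound 1 differs from the others in more than one place, so its number cannot be tied to any single group.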